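Swapping the arylidene group on a shared urea core

The source may report more compounds than this note shows. Statements on the series, on what has been measured and on what is new or still open speak of the compounds shown alone.

Three compounds share one core and differ only in the aryl group on the carbon with a double bond to nitrogen. Compound 1 `CN(C)CCn1cnnc1-c1cc(Oc2ccc(NC(=O)N/N=C/c3ccc(Cl)cc3Cl)cc2F)ccn1` gives 2330 nM in a functional assay on U-87MG ATCC cells (Homo sapiens) for cytotoxicity, read by MTT assay, with a stated time of 72 h; a lower number here means a stronger inhibitor, a higher number a weaker inhibitor. Compound 3 `CN(C)CCn1cnnc1-c1cc(Oc2ccc(NC(=O)N/N=C/c3ccc(F)cc3F)cc2F)ccn1` gives 1900 nM in this assay, and compound 2 `COc1ccc(OC)c(/C=N/NC(=O)Nc2ccc(Oc3ccnc(-c4nncn4CCN(C)C)c3)c(F)c2)c1` gives 6400 nM. Compound 2 therefore stands with the highest number of the three: a 2.7-fold higher number from compound 1 to compound 2 (0.44 log units; beyond the scatter), and a 3.4-fold lower number from compound 2 to compound 3 (0.53 log units; beyond the scatter), while a 1.2-fold lower number from compound 1 to compound 3 (0.09 log units; within the scatter).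

Compound 4 `COc1cc(/C=N/NC(=O)Nc2ccc(Oc3ccnc(-c4nncn4CCN(C)C)c3)c(F)c2)cc(OC)c1OC` has not yet been measured. It differs from compound 2 in one place: 3,4,5-trimethoxyphenyl in place of 2,5-dimethoxyphenyl on a carbon with a double bond to nitrogen. Both steps that touch this position, from compound 1 to compound 2 and from compound 2 to compound 3, exchanged a dimethoxyphenyl for a dihalophenyl, and each moved the number by a modest amount beyond the scatter, with the dimethoxyphenyl giving the higher number. Within the data shown here, no step exchanges one methoxyphenyl pattern for another, so there is no direct guide for compound 4. The expectation is therefore a number close to that of compound 2, with wide uncertainty, and the estimated step is a 1.1-fold higher number from compound 2 to compound 4 (0.04 log units; within the scatter). For compound 4 the expected value in this assay is 7000 nM, with a range from 2500 nM to 20000 nM.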

Compound 4, half-maximal inhibitory concentration: 22500 nM
Beside the measured number, compound 4's estimate is 3.2-fold (0.51 log units) below it; measured number above the stated range.
By their numbers in this assay, from the lowest: compounds 3 and 1 (each within the scatter of the next); then compound 2; then compound 4.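

Until now, every step at this position exchanged a dimethoxyphenyl for a dihalophenyl, but in this assay one methoxyphenyl pattern exchanged for another also shifts the number, with a 3.5-fold higher number from compound 2 to compound 4 (0.55 log units; beyond the scatter) as the 3,4,5-trimethoxyphenyl replaces the 2,5-dimethoxyphenyl on the carbon with a double bond to nitrogen. The full spread at this single position is also wider than the first three compounds suggested, with a 12-fold higher number from compound 3 to compound 4 (1.07 log units; beyond the scatter) and a 9.7-fold higher number from compound 1 to compound 4 (0.98 log units; beyond the scatter) when the 3,4,5-trimethoxyphenyl replaces a dihalophenyl, which makes compound 4 the weakest of the four. Nothing available here explains why the 3,4,5-trimethoxyphenyl gives the highest number.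

This change alters both how many methoxy groups the ring carries and where they stand, so the two compounds cannot show which of these matters. The compounds shown also leave open how the shared core would respond to an unsubstituted phenyl, or to a phenyl carrying a hydroxyl group, an amine or a carboxylic acid.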